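The compounds below may be only part of what the source reports. "The series", "measured", "known", "first", "only" and "open" are said of these compounds alone.

Measured compounds in an assay for inhibition of Fatty-acid amide hydrolase 1 (Rattus norvegicus); on this read-out higher numbers stand for weaker inhibition and lower numbers for stronger inhibition:
- compound 1 `O=C(O)c1cccc(CCCCCCC(=O)c2ncc(-c3ccccn3)o2)c1` gives > 600 nM, a limit of the assay.
- compound 2 `O=C(O)c1ccc(CCCCCCC(=O)c2ncc(-c3ccccn3)o2)cc1` gives > 600 nM, again a limit of the assay.
- compound 3 `Nc1ccc(CCCCCCC(=O)c2ncc(-c3ccccn3)o2)cc1` gives 3 nM.

Compound 1 stands at the limit rather than at a number (the limit of > 600 nM in this assay, at which 2 of the 3 values shown sit); only compound 3 gives a read number, and the step of an at least 200-fold lower number from compound 1 to compound 3 (2.30 log units; beyond the scatter) is the one firm ordering among the three. The step that the two limits leave unreadable from compound 1 to compound 2 is unreadable. The step of an at least 200-fold lower number from compound 2 to compound 3 (2.30 log units; beyond the scatter) shows that exchanging the carboxy for an amino on the aromatic carbon takes the series from the limit to a strong inhibitor; together with an at least 200-fold lower number from compound 1 to compound 3 (2.30 log units; beyond the scatter) this is the evidence that bears on the present change.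

Compound 4 `CC(C)(C)OC(=O)Nc1cccc(CCCCCCC(=O)c2ncc(-c3ccccn3)o2)c1` is not yet measured. Its change from compound 1 is (tert-butoxycarbonyl)amino in place of carboxy on an aromatic carbon. The carboxy is removed, as in both steps that reached compound 3, but what enters is (tert-butoxycarbonyl)amino, not amino, and it sits meta to the large group rather than where compound 3 carries its amino. A step downward beyond the scatter is therefore expected for compound 4, though smaller than the step to compound 3; the expected step is an at least 15-fold lower number from compound 1 to compound 4 (1.17 log units; beyond the scatter). For compound 4 in this assay a value of 40 nM is estimated, with a range from 5 nM to 400 nM.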

Compound 4, inhibition constant: 2.4 nM
Compound 4: middle estimate off by 17-fold (1.22 log units), on the high side; measured number below the stated range.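

In this assay, among these compounds, the place meta to a large group, so far seen only with carboxy, also carries (tert-butoxycarbonyl)amino, a group of 8 heavy atoms against 3, and the change gives an at least 250-fold lower number from compound 1 to compound 4 (2.39 log units; beyond the scatter). Among the compounds shown, a low number is therefore no longer tied to the 4-aminophenyl of compound 3, and both compounds with a carboxy remain at the limit while both without one read low. The size of the new step is a bound and not a measure, because compound 1 stands at a limit of the assay: the limit of > 600 nM in this assay, at which 2 of the 4 values shown sit.

From the compounds shown here alone, the step between compound 1 and compound 2 cannot be read, so any effect of where the carboxy sits stays open. Also open, going by these compounds, is whether the low number of compound 4 comes from losing the carboxy or from what enters, a question that a plain amine or an unsubstituted phenyl at this place would separate, as would (tert-butoxycarbonyl)amino where compound 3 carries its amino.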